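The source may hold more compounds than are shown below. What is called first, only, known or untested is meant among the compounds shown, and "the series" means these compounds.

Compound 1, `COc1cc[nH]c1/C=C1\C(=O)Nc2ccc([N+](=O)[O-])c(N3CCC(O)CC3)c21`: 46 nM
Compound 2, `COc1cc[nH]c1/C=C1\C(=O)Nc2ccc([N+](=O)[O-])c(N3CC[C@@H](O)C3)c21`: 88 nM

In a functional assay on MDA-MB-435 cells (Homo sapiens) for antiproliferative activity, read by MTT assay, with a stated time of 5 days (on this read-out higher numbers stand for weaker inhibition and lower numbers for stronger inhibition), compound 1 gives 46 nM, and compound 2 gives 88 nM. Among the compounds with values here, of the two numbers, that of compound 2 is the higher, but the only step connecting them, a 1.9-fold higher number from compound 1 to compound 2 (0.28 log units; within the scatter), lies within the scatter, so the two compounds cannot be told apart on these data.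

Compound 3, `COc1cc[nH]c1/C=C1\C(=O)Nc2ccc([N+](=O)[O-])c(N3CCC(N)CC3)c21`, has not yet been measured in this assay. It differs from compound 2 by 4-aminopiperidin-1-yl in place of 3-hydroxypyrrolidin-1-yl on an aromatic carbon. Within the data shown here, the one measured step that bears on this change is a 1.9-fold higher number from compound 1 to compound 2 (0.28 log units; within the scatter), in which the six-membered hydroxylated ring of compound 1 was replaced by the five-membered one of compound 2 without a shift beyond the scatter. Among the measured compounds shown here, compound 3 returns to a six-membered ring and carries an amino group instead of a hydroxyl; no measured step covers the hydroxyl-to-amino exchange. Since the ring-size change produced only a 1.9-fold higher number from compound 1 to compound 2 (0.28 log units; within the scatter), compound 3 is expected to stay close to its neighbours, with a step of a 1.6-fold lower number from compound 2 to compound 3 (0.20 log units; within the scatter) that is expected to fall within the scatter. Compound 3 is therefore estimated at 55 nM, within the range 20 nM to 150 nM.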

Compound 3, half-maximal inhibitory concentration: < 10 nM
Compound 3: only a limit was reported; the forecaster's own chance of this, stated with the estimate: 2%; middle value at least 5.5-fold (0.74 log units) from the limit.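

Compound 3 stands at a limit of the assay and not at a number: the limit of < 10 nM in this assay, at which 1 of the 3 values shown sits. In this assay, amino in place of hydroxy on a saturated ring carbon, with the six-membered ring kept, gives an at least 4.6-fold lower number from compound 1 to compound 3 (0.66 log units; beyond the scatter), and the full exchange of 3-hydroxypyrrolidin-1-yl for 4-aminopiperidin-1-yl gives an at least 8.8-fold lower number from compound 2 to compound 3 (0.94 log units; beyond the scatter). The earlier step, a 1.9-fold higher number from compound 1 to compound 2 (0.28 log units; within the scatter), had shown no readable change, whereas these two show that the group on this aromatic carbon, ortho to a nitro group, can shift the read-out beyond the scatter when the hydroxy gives way to an amino group.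

Going by these compounds, how far compound 3 lies past its limit remains open, and with it the full size of both steps. The compounds shown also do not tell how a dimethylamino group or an aminomethyl group on the piperidine ring, or 3-aminopyrrolidin-1-yl, would compare.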